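Aryl ester series: chromone replaced by 2-phenylphenyl

A few compounds are considered here, and "the series" means these few. Any claim that something is new, unique, unknown or untested is made for them only; others in the source may bear on it.

The three compounds measured in an in vitro functional assay on HEK ts201 cells for antagonist activity at Neuronal acetylcholine receptor; alpha4/beta2 (Homo sapiens), read by fluorescence and calcium flux (on this read-out higher numbers stand for weaker inhibition and lower numbers for stronger inhibition), so far all sit at the weak end. Compound 1 `O=C(Nc1ccccn1)c1ccccc1-c1ccccc1` gives 13600 nM; compound 2 `COc1ccc(OCCCCCN2CCCC(COC(=O)c3coc4ccccc4c3=O)C2)cc1` gives 10000 nM; compound 3 `C[C@@H]1CC(=O)N(c2ccccc2C(=O)OC[C@@H]2CCCN(CCCc3ccccc3)C2)C1=O` gives 8910 nM. Compound 2 is within the scatter of both other compounds in this assay: the gap to compound 3 and the gap to compound 1 are each smaller than the usual spread of repeated measurements, so no order can be read among the three.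

Compound 4 `COc1ccc(OCCCCCN2CCCC(COC(=O)c3ccccc3-c3ccccc3)C2)cc1` keeps the methoxyphenoxy-pentyl piperidinylmethyl portion of compound 2 and changes only the acid part of the ester: a group of 12 heavy atoms (12 carbon; 2 six-membered aromatic rings of carbon only) in place of a group of 11 heavy atoms (9 carbon, 2 oxygen; one six-membered aromatic ring of carbon only, one six-membered aromatic ring with 1 hetero atom), on a carbonyl carbon. The same 2-phenylphenyl carbonyl unit appears in compound 1, there as an amide to a pyridine nitrogen rather than as an ester, and compound 1 is a weak inhibitor in this assay. Going by the values given here, no pair of measured compounds differs in exactly this way, so no measured step is available for it.

Among the compounds with values here, on these numbers a step from compound 2 to compound 4 of no more than the scatter is expected in this assay, in either direction, since the one compound carrying the entering group, compound 1, gives 13600 nM. The estimate for compound 4 is 10000 nM, with a range from 3500 nM to 30000 nM, which corresponds to an expected step of no change at the digits printed from compound 2 to compound 4 (within the scatter).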

Compound 4, half-maximal inhibitory concentration: 14500 nM
Beside the measured number, compound 4's estimate is 1.5-fold (0.16 log units) below it, within the range that was stated.
By their numbers in this assay, from the lowest: compounds 3, 2, 1 and 4 (each within the scatter of the next).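

Working notes on the acid part of the ester: the first measured step at this position, on a carbonyl carbon, reads a 1.5-fold higher number from compound 2 to compound 4 (0.16 log units; within the scatter) in this assay. Within the scatter, this assay does not separate the 2-phenylphenyl group, with 2 six-membered aromatic rings of carbon only and 0 hydrogen-bond acceptors, from the group it replaces, which has one six-membered aromatic ring with 1 hetero atom and 2 hydrogen-bond acceptors. For this one pair, then, the ring hetero atom and the acceptors of the leaving group show no effect that can be read on this read-out, and no supporting measurement is available to interpret the result further.

On these data alone, it remains open whether any other group at this carbonyl carbon, such as cyclohexyl or a ring bearing a basic amine or a carboxylic acid, would give a step beyond the scatter from compound 2 in this assay. As far as these compounds go, it is also open whether a shorter propyl chain in place of the pentyl chain would change how this position responds, since a single step on one shared portion cannot show that.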